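Amide-linker series: piperidine versus ethylpiperazine, chain length

This account rests on a few compounds, and the source may have more. Where it says the series, first, only, none or still open, it means among the compounds named here.

Measured so far in a functional assay on HepG2 cells (Homo sapiens) for cytotoxicity, read by MTT assay, with a stated time of 72 h; on this read-out higher numbers stand for weaker inhibition and lower numbers for stronger inhibition:
compound 1 `CCN1CCN(CCC(=O)Nc2ccc3[nH]c(-c4ccc(C)cc4)nc3c2)CC1`: 14600 nM
compound 2 `Cc1ccc(-c2nc3cc(NC(=O)CCN4CCCCC4)ccc3[nH]2)cc1`: 11900 nM
compound 3 `Cc1ccc(-c2nc3cc(NC(=O)CN4CCCCC4)ccc3[nH]2)cc1`: > 50000 nM

The value of compound 3 in this assay is a limit of the assay and not a number, as marked by the limit of > 50000 nM in this assay, at which 1 of the 3 values shown sits. Compound 1 and compound 2 share the longer chain and differ by 4-ethylpiperazin-1-yl in place of piperidin-1-yl on a saturated chain carbon, two bonds along the chain from a carbonyl carbon; the step of a 1.2-fold higher number from compound 2 to compound 1 (0.09 log units; within the scatter). Compound 3 differs from compound 2 by piperidin-1-yl in place of (piperidin-1-yl)methyl on a saturated chain carbon bound to a carbonyl carbon, and here the step is an at least 4.2-fold higher number from compound 2 to compound 3 (0.62 log units; beyond the scatter). Compound 1 against compound 3 gives an at least 3.4-fold higher number from compound 1 to compound 3 (0.53 log units; beyond the scatter).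

Compound 4 `CCN1CCN(CC(=O)Nc2ccc3[nH]c(-c4ccc(C)cc4)nc3c2)CC1` is not yet measured in this assay. It differs from compound 3 by 4-ethylpiperazin-1-yl in place of piperidin-1-yl on a saturated chain carbon bound to a carbonyl carbon. This is the same kind of change as that from compound 2 to compound 1, though not the same: there the place is on a saturated chain carbon, two bonds along the chain from a carbonyl carbon, whereas here it is on a saturated chain carbon bound to a carbonyl carbon. The expected step is a step that the limit leaves unreadable from compound 3 to compound 4, since for compound 2 and compound 1 the same kind of change gave only a 1.2-fold higher number from compound 2 to compound 1 (0.09 log units; within the scatter). Compound 4 is therefore estimated at 60000 nM, with a range from 25000 nM to 150000 nM, and it is expected most often to come back as a limit rather than a number.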

Compound 4, half-maximal inhibitory concentration: 31900 nM
Beside the measured number, compound 4's estimate is 1.9-fold (0.27 log units) above it; measured number inside the range.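

In this assay, 4-ethylpiperazin-1-yl in place of piperidin-1-yl on the shorter chain gives an at least 1.5-fold lower number from compound 3 to compound 4 (0.19 log units; that floor lies within the scatter), and set beside the same change on the longer chain, the comparison reads: the same change on two cores in this assay, a 1.2-fold higher number (0.09 log units; within the scatter) from compound 2 to compound 1 and an at least 1.5-fold lower number (0.19 log units; that floor lies within the scatter) from compound 3 to compound 4; the limit leaves it open whether they differ. Compound 3 stands at a limit of the assay and not at a number, so the change can be neither said to carry over unchanged from one core to the other nor said to behave differently there: the limit of > 50000 nM in this assay, at which 1 of the 4 values shown sits. The steps that can be read in full concern the chain instead, with a 2.2-fold higher number from compound 1 to compound 4 (0.34 log units; beyond the scatter) where 4-ethylpiperazin-1-yl is kept, and a 2.7-fold higher number from compound 2 to compound 4 (0.43 log units; beyond the scatter) where 4-ethylpiperazin-1-yl on the shorter chain is set against the piperidin-1-yl compound on the longer chain.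

The compounds shown leave open the true size of the piperidin-1-yl to 4-ethylpiperazin-1-yl step on the shorter chain. They also leave open whether another amine, such as morpholine or dimethylamine, in the same place on a saturated chain carbon bound to a carbonyl carbon would match 4-ethylpiperazin-1-yl, and how a chain longer than that of compound 1 would read in this assay.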